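The source may hold more compounds than are shown below. What is called first, only, known or untested is meant among the compounds shown, and "the series" means these compounds.

Compound 2 `CCOC(=O)N1CCC(N2CCC[C@@H](NC(=O)C3CCCC3)C2)CC1` carries the shared core with a cyclopentyl on the carbonyl carbon of the amide. In a functional assay on CHO cells for agonist activity at muscarinic acetylcholine receptor M5 (Rattus norvegicus) (a higher number here means that more compound is needed for the effect, a lower number that less compound is needed), compound 2 gives only a limit, > 10000 nM. For the measured compounds named here, compound 1 `CCOC(=O)N1CCC(N2CCC[C@@H](NC(=O)c3cccc(OC)c3)C2)CC1` is the sole measured neighbour of compound 2. In this assay compound 1 likewise gives only a limit, > 10000 nM. The step from compound 1 to compound 2, a step that the two limits leave unreadable from compound 1 to compound 2, cannot be read, since both values sit at the limit of > 10000 nM in this assay, at which 2 of the 2 values shown sit. Compound 3 `CCOC(=O)N1CCC(N2CCC[C@@H](NC(=O)c3ccccc3)C2)CC1` differs from compound 2 by phenyl in place of cyclopentyl on a carbonyl carbon. Going by the values given here, no measured step bears on this change with a readable size; the one step known in this assay is unreadable, and both compounds measured so far sit at the limit of > 10000 nM in this assay, at which 2 of the 2 values shown sit. The expected step is therefore a step that the limit leaves unreadable from compound 2 to compound 3, with no direction that the data can support, and another limit is the likeliest outcome. Compound 3 is estimated at 20000 nM, with a range from 5000 nM to 80000 nM.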

Compound 3, half-maximal effective concentration: > 10000 nM
Compound 3 gave a limit, no number; the forecaster's own chance of this, stated with the estimate: 80%; the middle value does not contradict the limit.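

For the compounds shown here, no step among compound 1, compound 2 and compound 3 can be read in this assay, as each gives only a limit: the limit of > 10000 nM in this assay, at which 3 of the 3 values shown sit. The compounds shown leave open whether any amide substituent on the shared core gives a measurable effect, and how cyclopentyl, phenyl and 3-methoxyphenyl truly compare.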